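This account rests on a few compounds, and the source may have more. Where it says the series, first, only, none or still open, it means among the compounds named here.

Within the data shown here, compound 3 `Cc1ccc(OC(C)(C)C2OCC(C/C=C\CCC(=O)O)C(c3cccnc3)O2)cc1` is one of three compounds measured in an assay for inhibition of Thromboxane-A synthase (Homo sapiens), using microsomes; a higher number here means a weaker inhibitor, a lower number a stronger inhibitor. Compound 3 gives 360 nM, the second highest of the three numbers. The nearest is compound 1 `O=C(O)CC/C=C\CC1COC(c2ccsc2)OC1c1cccnc1`, which gives 500 nM; these two values lie within the scatter of each other. Compound 2 `O=C(O)CC/C=C\CC1COC(c2cccs2)OC1c1cccnc1` gives 71 nM, and the gap from compound 3 is beyond the scatter. Among the measured compounds shown here, the only step measured between neighbours is a 7.0-fold lower number from compound 1 to compound 2 (0.85 log units; beyond the scatter), which concerns the thiophenyl group on the shared core and nothing else.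

Compound 4 `CC(C)(Cc1ccc(F)cc1)C1OCC(C/C=C\CCC(=O)O)C(c2cccnc2)O1` has not yet been measured. Its difference from compound 3 is 4-fluorobenzyl in place of 4-methylphenoxy on a saturated chain carbon bound to two saturated chain carbons and a saturated ring carbon. No measured step touches this part of the molecule, so nothing seen so far tells how this assay answers a swap at that place; the one step shown lies elsewhere and is a different kind of change. The expectation therefore rests on compound 3 alone, with wide room either way. Compound 4 is expected to give about 300 nM, with a range from 90 nM to 1000 nM. This means a step of a 1.2-fold lower number from compound 3 to compound 4 (0.08 log units; within the scatter) is expected, no larger than the scatter.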

Compound 4, half-maximal inhibitory concentration: 45 nM
Compound 4: the middle estimate sits 6.7-fold (0.82 log units) above what was measured; the measured number lies below the stated range.
By their numbers in this assay, from the lowest: compounds 4 and 2 (each within the scatter of the next); then compounds 3 and 1 (each within the scatter of the next).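

In this assay, the swap at this position gives an 8.0-fold lower number from compound 3 to compound 4 (0.90 log units; beyond the scatter), so the assay responds clearly to a change on the saturated chain carbon bound to two saturated chain carbons and a saturated ring carbon, something the thiophenyl step could not show. The two groups have the same number of heavy atoms and one six-membered aromatic ring of carbon only, but the swap makes two changes at once: the oxygen of 4-methylphenoxy gives way to the carbon of the benzyl group, taking the hydrogen-bond acceptor count from one to none, and the methyl on the ring gives way to fluorine. No measurement at hand explains the size of this step or ties it to either change.

The compounds shown leave open which of the two changes carries the step, a question that 4-methylbenzyl or 4-fluorophenoxy at the same place could settle. They also leave open how an unsubstituted benzyl group, or a longer chain carrying the 4-fluorophenyl ring, would read in this assay.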